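Anilide variation in a triazolyl-thioacetamide orexin series

The source may report more compounds than this note shows. Statements on the series, on what has been measured and on what is new or still open speak of the compounds shown alone.

Measured so far in a functional assay on CHO cells for antagonist activity at Orexin receptor type 2 (Homo sapiens), read by FLIPR and calcium flux; on this read-out lower numbers stand for stronger inhibition and higher numbers for weaker inhibition:
- compound 1, `Cc1cccc(NC(=O)CSc2nnc(-c3ccoc3C)n2Cc2ccco2)c1`: 50.1 nM
- compound 2, `Cc1occc1-c1nnc(SCC(=O)Nc2ccc(F)cc2)n1Cc1ccco1`: 158 nM
- compound 3, `CC(=O)c1ccc(NC(=O)CSc2nnc(-c3ccoc3C)n2Cc2ccco2)cc1`: 31.6 nM

Compound 2 stands at the highest number of the three; the nearest step, read in reverse, is a 3.2-fold higher number from compound 1 to compound 2 (0.50 log units; beyond the scatter), and the furthest is compound 3 with a 5.0-fold lower number from compound 2 to compound 3 (0.70 log units; beyond the scatter). The shared core is kept throughout and only the aryl group on the amide-type nitrogen changes.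

Compound 4, `CC(=O)c1cccc(NC(=O)CSc2nnc(-c3ccoc3C)n2Cc2ccco2)c1`, is not yet measured. The change from compound 2 reads (3-acetylphenyl in place of 4-fluorophenyl on an amide-type nitrogen).

Among the compounds with values here, two measured steps bear on it. Exchanging the 4-fluorophenyl for a substituted phenyl has so far placed the lower number on the substituted-phenyl side both times: a 3.2-fold higher number from compound 1 to compound 2 (0.50 log units; beyond the scatter) (read in reverse) and a 5.0-fold lower number from compound 2 to compound 3 (0.70 log units; beyond the scatter). The comparison of a 3-substituted phenyl with a 4-acetylphenyl, a 1.6-fold lower number from compound 1 to compound 3 (0.20 log units; within the scatter), stays within the scatter, so the acetyl in the 3-position is expected to sit somewhere between those two outcomes. A modest step downward in this assay is therefore expected for compound 4, of the order of a 3.5-fold lower number from compound 2 to compound 4 (0.55 log units; beyond the scatter). The estimate for compound 4 is 45 nM, with an expected range from 20 nM to 110 nM.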

Compound 4, inhibition constant: 316 nM
For compound 4 the middle estimate is 7.0-fold (0.85 log units) below the measured one; the whole stated range lies below it.
By their numbers in this assay, from the lowest: compounds 3 and 1 (each within the scatter of the next); then compounds 2 and 4 (each within the scatter of the next).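

In this assay, the placing of the acetyl on the aryl group matters, which compounds 1 to 3 could not show: 3-acetylphenyl in place of 4-acetylphenyl on the amide-type nitrogen gives a 10-fold higher number from compound 3 to compound 4 (1.00 log units; beyond the scatter), so the acetyl group cannot be read apart from where it sits. Acetyl in place of methyl gives a 6.3-fold higher number from compound 1 to compound 4 (0.80 log units; beyond the scatter), so 3-acetylphenyl does not follow the 3-methylphenyl of compound 1 either. Against 4-fluorophenyl the exchange gives a 2.0-fold higher number from compound 2 to compound 4 (0.30 log units; within the scatter), which stays within the scatter, so compound 4 goes against the earlier picture of substituted phenyl groups lying clearly below compound 2, and no measurement at hand accounts for these differences.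

Going by these compounds, it remains open whether the gap between 3-acetylphenyl and 4-acetylphenyl is particular to acetyl or also appears with a nitrile, a carboxylic acid or a methoxy group on the same aryl ring. Also open is where an unsubstituted phenyl group would stand, as the shown compounds offer no such baseline for reading any of these substituents.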